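The compounds below may be only part of what the source reports. "The series", "measured", "known", "first", "only" and "open" are said of these compounds alone.

Of the compounds shown here, three sharing one core have been tested in a functional assay on B16-F10 cells (Mus musculus) for inhibition, read by MTT assay, with a stated time of 48 h; a lower number here means a stronger inhibitor, a higher number a weaker inhibitor. Compound 1 `O=C(/C=C/c1ccc([N+](=O)[O-])cc1)Nc1ccc2ncnc(Nc3cccc(Br)c3)c2c1` gives 0.982 ug/mL. Compound 2 `O=C(/C=C/c1ccc(Cl)cc1)Nc1ccc2ncnc(Nc3cccc(Cl)c3)c2c1` gives 9.97 ug/mL, and compound 3 `O=C(/C=C/c1cccs1)Nc1ccc2ncnc(Nc3cccc(Cl)c3)c2c1` gives 4.26 ug/mL. Compound 3 thus stands second highest of the three numbers, with compound 2 nearer to it and compound 1 further away. Among the compounds with values here, the one measured step between neighbours, a 2.3-fold lower number from compound 2 to compound 3 (0.37 log units; beyond the scatter), is modest. Compound 4 `O=C(/C=C/c1ccc([N+](=O)[O-])cc1)Nc1ccc2ncnc(Nc3cccc(Cl)c3)c2c1` differs from compound 3 by 4-nitrophenyl in place of thiophen-2-yl on a double-bonded chain carbon bound to a double-bonded chain carbon. Within the data shown here, no measured step swaps a thiophen-2-yl for a 4-nitrophenyl, but the same 4-nitrophenyl is carried, with a bromine where compound 3 has a chlorine, by compound 1, which gives 0.982 ug/mL. Compound 4 is therefore expected to move to a lower number, a 2.8-fold lower number from compound 3 to compound 4 (0.45 log units; beyond the scatter), estimated at 1.5 ug/mL, within 0.5 ug/mL to 4.5 ug/mL.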

Compound 4, half-maximal inhibitory concentration: 2.05 ug/mL
Estimate against measurement, compound 4: 1.4-fold (0.14 log units) below, and the stated range covers the measured number.
By their numbers in this assay, from the lowest: compound 1; then compound 4; then compound 3; then compound 2.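

In this assay the 4-nitrophenyl gives a lower number than thiophen-2-yl on this chain carbon (a 2.1-fold lower number from compound 3 to compound 4 (0.32 log units; beyond the scatter)), and nitro in place of chloro on the aromatic carbon of the phenyl ring lowers it further (a 4.9-fold lower number from compound 2 to compound 4 (0.69 log units; beyond the scatter)). The halogen on the other aromatic carbon matters as well, with chloro in place of bromo raising the number (a 2.1-fold higher number from compound 1 to compound 4 (0.32 log units; beyond the scatter)), so the low value of compound 1 does not rest on the 4-nitrophenyl alone. Nothing measured here gives a reason for these steps.

Still open, going by these compounds, is how a 4-aminophenyl or a 4-carboxyphenyl would compare with the 4-nitrophenyl at this place. Also open, on these data alone, is whether bromo in place of chloro gives a similar step alongside thiophen-2-yl or 4-chlorophenyl.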